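This account rests on a few compounds, and the source may have more. Where it says the series, first, only, none or still open, it means among the compounds named here.

Of the compounds shown here, three built on a shared core have been measured in a functional assay on T47D cells (Homo sapiens) for cytotoxicity, read by CCK-8 assay; a lower number here means a stronger inhibitor, a higher number a weaker inhibitor. Compound 1 `Oc1cccc(-c2cc(-c3cccs3)cc(-c3cccc(O)c3)n2)c1` gives 770 nM. Compound 2 `Oc1ccc(-c2cc(-c3cccs3)cc(-c3cccc(O)c3)n2)cc1` gives 780 nM in this assay; the change between them is 4-hydroxyphenyl in place of 3-hydroxyphenyl on an aromatic carbon and the step is a 1.0-fold higher number from compound 1 to compound 2 (0.01 log units; within the scatter). Compound 3 `Oc1ccc(-c2cc(-c3ccsc3)cc(-c3cccc(O)c3)n2)cc1` gives 760 nM in this assay, with the step of a 1.0-fold lower number from compound 2 to compound 3 (0.01 log units; within the scatter). The difference between the cores of compound 1 and compound 3 is not broken down here. Compound 4 `Oc1ccc(-c2cc(-c3ccsc3)cc(-c3ccc(O)cc3)n2)cc1` is not yet measured; it differs from compound 3 by 4-hydroxyphenyl in place of 3-hydroxyphenyl on an aromatic carbon. This is the same kind of change as before, though the place differs: earlier it was meta to a 3-hydroxyphenyl group and a thiophen-2-yl group, here meta to a 4-hydroxyphenyl group and a thiophen-3-yl group. Because the earlier step of a 1.0-fold higher number from compound 1 to compound 2 (0.01 log units; within the scatter) lay within the scatter, the step from compound 3 to compound 4 is expected to be about a 1.0-fold higher number from compound 3 to compound 4 (0.01 log units; within the scatter). Compound 4 is therefore expected to give about 770 nM, estimated between 400 nM and 1500 nM.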

Compound 4, half-maximal inhibitory concentration: 1770 nM
Compound 4: middle estimate off by 2.3-fold (0.36 log units), on the low side; measured number above the stated range.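

Replacing 3-hydroxyphenyl with 4-hydroxyphenyl on the core of compound 3 gives a 2.3-fold higher number from compound 3 to compound 4 (0.37 log units; beyond the scatter) in this assay, so compound 4 is a modestly weaker inhibitor. For the compounds shown here, the same change made earlier on another core can be set beside this step, and the gap between the two is no larger than repeat measurements could produce: the same change on two cores in this assay, a 1.0-fold higher number (0.01 log units; within the scatter) from compound 1 to compound 2 and a 2.3-fold higher number (0.37 log units; beyond the scatter) from compound 3 to compound 4, 2.3-fold (0.36 log units) apart, within the scatter of two such steps With only two pairs and a gap of this size, the data neither show that the core alters the effect of this change nor prove that the effect carries over unchanged. The compounds shown leave open how a methoxy group or an amine in place of the hydroxyl group would behave. They also leave open what a furan ring in place of the thiophene would do.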